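Swapping the aryl group on the imine carbon

The source may report more compounds than this note shows. Statements on the series, on what has been measured and on what is new or still open speak of the compounds shown alone.

Measured so far:
- compound 1 `CCCCc1oc2ccc(/N=C/c3ccc(C#N)cc3)cc2c1C(=O)c1ccc(OC)cc1` — 27.2 ug/mL
- compound 2 `CCCCc1oc2ccc(/N=C/c3ccc(OC)cc3OC)cc2c1C(=O)c1ccc(OC)cc1` — 20.5 ug/mL

Compound 1 and compound 2 share one core and differ only in the aryl group attached to the carbon that carries a double bond to nitrogen. In a functional assay, with a stated time of 30 min (a higher number here means a weaker inhibitor, a lower number a stronger inhibitor), compound 2 gives 20.5 ug/mL. This is the lower of the two numbers, yet the step of a 1.3-fold lower number from compound 1 to compound 2 (0.12 log units; within the scatter) lies within the scatter, so compound 1 and compound 2 are not separated by this assay.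

Compound 3 `CCCCc1oc2ccc(/N=C/c3ccc([N+](=O)[O-])cc3)cc2c1C(=O)c1ccc(OC)cc1` is not yet measured. It differs from compound 2 in one place: 4-nitrophenyl in place of 2,4-dimethoxyphenyl on a carbon with a double bond to nitrogen. Among the measured compounds shown here, the only measured step bears on this change indirectly, since it also exchanges the aryl group at the same place, and that step, a 1.3-fold lower number from compound 1 to compound 2 (0.12 log units; within the scatter), was within the scatter. Nothing else is known about a 4-nitrophenyl group here. The expectation is therefore a number close to that of compound 2, with no step beyond the scatter in this assay, and the estimated step is a 1.2-fold higher number from compound 2 to compound 3 (0.07 log units; within the scatter). Compound 3 is estimated at 24 ug/mL, with a range from 10 ug/mL to 55 ug/mL.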

Compound 3, half-maximal inhibitory concentration: 53.1 ug/mL
The estimate for compound 3 lay 2.2-fold (0.34 log units) below the measured number; measured number inside the range.
By their numbers in this assay, from the lowest: compounds 2, 1 and 3 (each within the scatter of the next, the first and the last beyond it).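

In this assay the aryl group on a carbon with a double bond to nitrogen now separates two compounds: the change from 2,4-dimethoxyphenyl to 4-nitrophenyl gives a 2.6-fold higher number from compound 2 to compound 3 (0.41 log units; beyond the scatter), a modest step, but the first at this place to lie beyond the scatter. The separation holds for that pair alone, since exchanging cyano for nitro on an aromatic carbon gives a 2.0-fold higher number from compound 1 to compound 3 (0.29 log units; within the scatter), so the three compounds form a shallow spread in which only the two ends can be told apart. Why the two end groups differ in this assay cannot be said, as no supporting measurement of any kind accompanies these numbers.

Because 2,4-dimethoxyphenyl and 4-nitrophenyl differ in more than one feature, the compounds shown leave open whether the step follows the loss of the two methoxy groups, the arrival of the nitro group, or both, and a plain phenyl or a single methoxy group would help to divide these. On these data alone, how an amine or a carboxylic acid on this aryl ring would read in this assay also remains open.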